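The source may report more compounds than this note shows. Statements on the series, on what has been measured and on what is new or still open speak of the compounds shown alone.

Measured compounds:

compound 1 `Nc1nc2c(c(-c3ccco3)cn2[C@@H]2O[C@H](CO)[C@@H](O)[C@H]2O)c(=O)[nH]1` in a functional assay on K562 cells (Homo sapiens), read by MTT assay, with a stated time of 72 h (on this read-out lower numbers stand for stronger inhibition and higher numbers for weaker inhibition), gives > 20000 nM, which is a limit of the assay and not a number.
compound 2 `Nc1nc2c(c(-c3cc4ccccc4o3)cn2[C@@H]2O[C@H](CO)[C@@H](O)[C@H]2O)c(=O)[nH]1` in this assay gives > 20000 nM, again a limit.
compound 3 `CNc1ncnc2c1c(-c1cc3ccccc3o1)cn2[C@@H]1O[C@H](CO)[C@@H](O)[C@H]1O` in this assay gives > 20000 nM, again a limit.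

Among the compounds with values here, the one change made twice in this set is furan-2-yl in place of 1-benzofuran-2-yl on an aromatic carbon. From compound 2 to compound 1 it gives a step that the two limits leave unreadable from compound 2 to compound 1, since both ends sit at a limit; what is known of the three measured values is the limit of > 20000 nM in this assay, at which 3 of the 3 values shown sit, and none of them is a number. How the core of compound 3 differs from that of compound 2 is not broken down here.

Compound 4 `CNc1ncnc2c1c(-c1ccco1)cn2[C@@H]1O[C@H](CO)[C@@H](O)[C@H]1O` is not yet measured in this assay. It differs from compound 3 by furan-2-yl in place of 1-benzofuran-2-yl on an aromatic carbon, the same change as from compound 2 to compound 1, at a place described in the same words. The step from compound 3 to compound 4 is expected to be a step that the limit leaves unreadable from compound 3 to compound 4, resting on the fact that the earlier step from compound 2 to compound 1 ran between two limits, and on compound 3 itself standing at the limit > 20000 nM. Compound 4 is therefore expected to give about 30000 nM in this assay, with a range of 15000 nM to 80000 nM, and most probably only a limit will be reported.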

Compound 4, half-maximal inhibitory concentration: 220 nM
Beside the measured number, compound 4's estimate is 140-fold (2.13 log units) above it, outside the stated range (below it).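

In this assay, furan-2-yl in place of 1-benzofuran-2-yl on the core of compound 3 gives an at least 90-fold lower number from compound 3 to compound 4 (1.95 log units; beyond the scatter), and that size is only a lower bound on the true step. Compound 3 gives > 20000 nM, which is a limit of the assay and not a number. The same change on the core of compound 2 leaves compound 1 at a limit as well, so that step cannot be read; the change therefore yields a measured number on one core only, compound 1 goes against any general rule, and the reading rests on a single pair, with the rest of the set at a limit: the limit of > 20000 nM in this assay, at which 3 of the 4 values shown sit.

Open, as far as these compounds go, is whether the measured number belongs to furan-2-yl alone, which a thiophen-2-yl or a plain phenyl group at the same aromatic carbon of the core of compound 4 would test. Also open, from the compounds shown here alone, is how much the methylamino group of compound 4 contributes, which a dimethylamino or a methoxy group in its place would address, with furan-2-yl kept unchanged.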